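The source may hold more compounds than are shown below. What is called first, only, known or untested is meant among the compounds shown, and "the series" means these compounds.

Working notes on the series.

Compound 1 `O=C(/C=C/c1ccc(F)c(Cl)c1)c1ccc(B(O)O)cc1` gives 6000 nM in a functional assay on MCF7 cells (Homo sapiens) for inhibition (on this read-out higher numbers stand for weaker inhibition and lower numbers for stronger inhibition), the lowest of the three numbers at hand. Compound 2 `O=C(/C=C/c1ccc(F)c(F)c1)c1ccc(B(O)O)cc1` gives 7800 nM in this assay, and compound 3 `O=C(/C=C/c1ccc(I)cc1)c1ccc(OCB(O)O)cc1` gives 9500 nM; the step of a 1.3-fold higher number from compound 1 to compound 2 (0.11 log units; within the scatter) is within the scatter, and the gap from compound 1 to compound 3 is likewise within the scatter, so no order among the three can be read.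

Compound 4 `O=C(/C=C/c1ccc(Cl)c(Cl)c1)c1ccc(B(O)O)cc1` is not yet measured. It differs from compound 1 by chloro in place of fluoro on an aromatic carbon, on an aromatic carbon of a six-membered aromatic ring of carbon only, ortho to a chloro group and para to a large group. Among the measured compounds shown here, the only step that bears on a halogen swap on this ring is a 1.3-fold higher number from compound 1 to compound 2 (0.11 log units; within the scatter), fluoro for chloro at the other halogen-bearing carbon, and it stayed within the scatter. For the measured compounds named here, no step in this assay exceeded the scatter for any change. The step of a 1.1-fold lower number from compound 1 to compound 4 (0.04 log units; within the scatter) is therefore expected to remain within the scatter, in no firm direction. Compound 4 is estimated at 5500 nM in this assay, with a range from 2200 nM to 14000 nM.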

Compound 4, half-maximal inhibitory concentration: 5000 nM
Estimate against measurement, compound 4: 1.1-fold (0.04 log units) above, and the stated range covers the measured number.
By their numbers in this assay, from the lowest: compounds 4, 1, 2 and 3 (each within the scatter of the next).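

Chloro in place of fluoro on this aromatic carbon, ortho to a chloro group and para to a large group, gives a 1.2-fold lower number from compound 1 to compound 4 (0.08 log units; within the scatter) in this assay. This position now has a direct reading, and the exchange of one halogen for the other does not separate compound 1 from compound 4. The other halogen swap at hand, a 1.3-fold higher number from compound 1 to compound 2 (0.11 log units; within the scatter), also stays within the scatter, so neither swap on compound 1 moves the number beyond it, and no information at hand accounts for this result.

The compounds shown leave open whether an amine, a carboxylic acid or a methoxy group on this carbon would give a step beyond the scatter. They also leave open whether a hydrogen here, with no halogen at all, would separate from compound 1.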